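This account rests on a few compounds, and the source may have more. Where it says the series, first, only, none or still open, it means among the compounds named here.

Series notes. For the measured compounds named here, compound 1 `CCCCNc1cc(Cl)nc(SC(C(=O)O)c2cccc3ccccc23)n1` is the weaker of the two compounds measured so far: in an assay on isolated protein for inhibition of Polyunsaturated fatty acid 5-lipoxygenase (Homo sapiens) (a higher number here means a weaker inhibitor, a lower number a stronger inhibitor), compound 1 gives 2400 nM, the highest of the two numbers. The nearest neighbour is compound 2 `O=C(Nc1ccc(Nc2cc(Cl)nc(SC(C(=O)O)c3cccc4ccccc34)n2)cc1)c1ccccc1`, which in this assay gives 600 nM, a gap beyond the scatter. Compound 3 `O=C(O)C(Sc1nc(Cl)cc(NCCCc2ccccc2)n1)c1cccc2ccccc12` has not been measured; it differs from compound 1 in one place: phenyl in place of methyl on a saturated chain carbon, three bonds along the chain from a nitrogen on an aromatic ring. Going by the values given here, no measured pair shows this exact change, so the step from compound 1 to compound 3 has no direct precedent in the data. The lower number of compound 2 in this assay is the only hint that more bulk on the amine side is tolerated, and it is an indirect one. The step from compound 1 to compound 3 is therefore expected to be a modest gain, a 2.4-fold lower number from compound 1 to compound 3 (0.38 log units; beyond the scatter), with a real chance of no change beyond the scatter. For compound 3 the estimate in this assay is 1000 nM, in the range 300 nM to 3000 nM.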

Compound 3, half-maximal inhibitory concentration: 1800 nM
Estimate against measurement, compound 3: 1.8-fold (0.26 log units) below; measured number inside the range.
By their numbers in this assay, from the lowest: compound 2; then compounds 3 and 1 (each within the scatter of the next).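

In this assay the chain on the nitrogen of the core can end in phenyl instead of methyl, which turns the butyl of compound 1 into the 3-phenylpropyl of compound 3, and the result is a 1.3-fold lower number from compound 1 to compound 3 (0.12 log units; within the scatter). At this position, then, six carbons and an aromatic ring enter without a change beyond the scatter, so this change gives no readable gain. Nothing available bears on why the step is so small.

Open, from the compounds shown here alone, is whether benzyl or phenethyl on the same nitrogen would behave like 3-phenylpropyl. Going by these compounds, it is also open whether a terminal amine or a carboxylic acid at the end of the chain would move the number beyond the scatter in this assay.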